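Aryl swap at the amine-bearing chain carbon: compound 4

A few compounds are considered here, and "the series" means these few. Any claim that something is new, unique, unknown or untested is made for them only; others in the source may bear on it.

Compound 1 `O=S(=O)(NCCCCNCc1ccc(Br)cc1)c1cc(C(F)(F)F)cc(C(F)(F)F)c1` and compound 2 `O=S(=O)(NCCCNCc1ccc(Br)cc1)c1cc(C(F)(F)F)cc(C(F)(F)F)c1` share their core with compound 3 `O=S(=O)(NCCCNCc1cccc2ccccc12)c1cc(C(F)(F)F)cc(C(F)(F)F)c1`. In a functional assay on ASPC1 cells (Homo sapiens) for inhibition, read by MTT assay, with a stated time of 72 h (a higher number here means a weaker inhibitor of growth, a lower number a stronger inhibitor of growth), compound 1 gives 2900 nM, compound 2 gives 2800 nM and compound 3 gives 21000 nM, the highest of the three numbers and the weakest inhibitor of growth here. Among the compounds with values here, the chain step a 1.0-fold lower number from compound 1 to compound 2 (0.02 log units; within the scatter) lies within the scatter; the aryl swap a 7.5-fold higher number from compound 2 to compound 3 (0.88 log units; beyond the scatter) is the only step that touches the group altered now. Compound 4 `COc1ccccc1CNCCCNS(=O)(=O)c1cc(C(F)(F)F)cc(C(F)(F)F)c1` carries 2-methoxyphenyl in place of naphthalen-1-yl on a saturated chain carbon bound to an amine nitrogen. Within the data shown here, the step from compound 2 to compound 3 shows that the aryl group at this carbon moves this assay beyond the scatter, but no measured pair shows 2-methoxyphenyl itself. A modest move back toward lower numbers is expected, a 2.6-fold lower number from compound 3 to compound 4 (0.42 log units; beyond the scatter). Compound 4 is thus estimated at 8000 nM, within 2500 nM to 25000 nM.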

Compound 4, concentration for 50% growth inhibition: 4600 nM
Beside the measured number, compound 4's estimate is 1.7-fold (0.24 log units) above it; the range from low to high includes it.
By their numbers in this assay, from the lowest: compounds 2, 1 and 4 (each within the scatter of the next); then compound 3.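

In this assay the step of a 4.6-fold lower number from compound 3 to compound 4 (0.66 log units; beyond the scatter) shows that the higher number at this saturated chain carbon bound to an amine nitrogen does not extend to 2-methoxyphenyl, which has one six-membered aromatic ring where naphthalen-1-yl has two. 2-Methoxyphenyl and 4-bromophenyl are not separated here (a 1.6-fold higher number from compound 2 to compound 4 (0.22 log units; within the scatter)), and the comparison with the butyl-chain compound reads the same (a 1.6-fold higher number from compound 1 to compound 4 (0.20 log units; within the scatter)), so among these four compounds only naphthalen-1-yl stands apart.

Going by these compounds, whether a carboxylic acid or an amine in place of the methoxy group would keep this level remains open. No supporting evidence explains the difference between the aryl groups.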